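The source may report more compounds than this note shows. Statements on the series, on what has been measured and on what is new or still open speak of the compounds shown alone.

Of the compounds shown here, three from this series have been measured so far. Compound 1 `FC(F)(F)C(F)(F)C(F)(F)C(F)(F)C(F)(F)C(F)(F)CCn1cc(COc2ccccc2-c2nc3ccccc3s2)nn1` gives 15100 nM in a functional assay on A549 cells (Homo sapiens) for cytotoxicity, read by MTT assay, with a stated time of 24 h; on this read-out lower numbers stand for stronger inhibition and higher numbers for weaker inhibition. Compound 2 `Fc1ccc(-n2cc(COc3ccccc3-c3nc4ccccc4s3)nn2)cc1` gives 23300 nM in this assay, and compound 3 `COc1cc(-c2cc(COc3ccccc3-c3nc4ccccc4s3)on2)cc(OC)c1OC` gives 22900 nM in this assay. On the numbers shown, compound 2 stands at the high end of the three, but compound 3 lies within the usual scatter of it and compound 1 lies within the scatter as well, so the three results cannot be told apart with confidence.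

The next compound, compound 4 `c1ccc(-n2cc(COc3ccccc3-c3nc4ccccc4s3)nn2)cc1`, has not yet been measured in this assay. It differs from compound 2 in one place only: hydrogen in place of fluoro on an aromatic carbon, which in a wider cut reads 4-fluorophenyl to phenyl, with the position described as para to a large group on a six-membered aromatic ring of carbon only.

For the measured compounds named here, no measured pair in this set spans the same change, so there is no step to lean on. Given how close the three measured numbers sit to one another, the step from compound 2 to compound 4 is expected to be small, a 1.1-fold lower number from compound 2 to compound 4 (0.02 log units; within the scatter), with no direction beyond the scatter. For compound 4 the estimate in this assay is 22000 nM, expected to fall between 10000 nM and 48000 nM.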

Compound 4, half-maximal inhibitory concentration: 16400 nM
For compound 4 the middle estimate is 1.3-fold (0.13 log units) above the measured one, within the range that was stated.
By their numbers in this assay, from the lowest: compounds 1, 4, 3 and 2 (each within the scatter of the next).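

For the compounds shown here, the first step between two measured compounds that differ in one place is now available in this assay: hydrogen in place of fluoro on an aromatic carbon, para to a large group, gives a 1.4-fold lower number from compound 2 to compound 4 (0.15 log units; within the scatter). At this position, then, the 4-fluorophenyl and phenyl forms cannot be told apart on this read-out, and this single pair gives no sign that the fluoro makes a readable difference. Nothing available bears on why the two results sit so close.

Fluoro and hydrogen are only two of the groups that could stand on this carbon, so the pair does not show how an amine, a carboxylic acid or a chloro group at the same place would read. It also leaves open whether the same change would stay within the scatter on a differently substituted ring, or whether a group with a longer chain at this position would give a step beyond it.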